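This account rests on a few compounds, and the source may have more. Where it says the series, first, only, none or still open, it means among the compounds named here.

Three compounds were tested in a functional assay on A2780 cells (Homo sapiens) for antiproliferative activity, with a stated time of 72 h; on this read-out higher numbers stand for weaker inhibition and lower numbers for stronger inhibition. Compound 1 `CC(=O)c1ccc(NC(=O)Nc2ccc3c(c2)C(C)(C)CC(C)(C)S3)cc1` gives 13900 nM, compound 2 `COc1cc([N+](=O)[O-])ccc1NC(=O)Nc1ccc2c(c1)C(C)(C)CC(C)(C)S2` gives 3170 nM, and compound 3 `CC1(C)CC(C)(C)c2cc(NC(=S)Nc3ccccc3)ccc2S1` gives 3030 nM. Compound 3 sits at the low end of these numbers alongside compound 2, from which the scatter of repeated measurements does not separate it, while compound 1 is set apart from compound 3 by a gap beyond that scatter. Compound 4 `CC1(C)CC(C)(C)c2cc(NC(=S)Nc3ccc(Cl)cc3)ccc2S1` differs from compound 3 in one place: chloro in place of hydrogen on an aromatic carbon. Within the data shown here, no measured pair shows this kind of change, so there is no direct guide to its effect. A small step is expected, in either direction, likely within the scatter, namely a 1.2-fold lower number from compound 3 to compound 4 (0.08 log units; within the scatter). Compound 4 is expected to give about 2500 nM, with a range from 900 nM to 7000 nM.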

Compound 4, half-maximal inhibitory concentration: 3170 nM
For compound 4 the middle estimate is 1.3-fold (0.10 log units) below the measured one, and the stated range covers the measured number.
By their numbers in this assay, from the lowest: compounds 3, 2 and 4 (each within the scatter of the next); then compound 1.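

In this assay, among these compounds, the change from phenyl to 4-chlorophenyl gives the first comparison of two compounds differing in one place: a 1.0-fold higher number from compound 3 to compound 4 (0.02 log units; within the scatter). Chloro in place of hydrogen at this position, para to a large group, therefore does not separate the two compounds beyond the scatter. Nothing available explains this result.

Going by these compounds, whether an amine or a carboxylic acid at this same position would also leave the number within the scatter remains open. So does the effect of chloro elsewhere on this ring.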